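Reversing the Amide Linker on a Triazole Chromone Series

The source may report more compounds than this note shows. Statements on the series, on what has been measured and on what is new or still open speak of the compounds shown alone.

Measured so far:
compound 1 `Cc1ccc(C(=O)NCc2cn(Cc3ccc4oc(-c5ccc(Cl)cc5)cc(=O)c4c3)nn2)cc1` — 32900 nM
compound 2 `Cc1ccc(NC(=O)CCc2cn(Cc3ccc4oc(-c5ccccc5)cc(=O)c4c3)nn2)cc1` — 15600 nM

In an assay on isolated protein for inhibition of Amine oxidase [flavin-containing] B (Homo sapiens), read by fluorescence and spectrophotometry (a lower number here means a stronger inhibitor, a higher number a weaker inhibitor), compound 1 gives 32900 nM, the highest of the two numbers recorded. Compound 2 gives 15600 nM, a lower number that lies beyond the usual scatter of the pair.

Compound 3 `O=C(CCc1cn(Cc2ccc3oc(-c4ccc(Cl)cc4)cc(=O)c3c2)nn1)Nc1ccccc1` has not yet been measured. It differs from compound 1 by (phenylcarbamoyl)methyl in place of ((4-methylphenyl)carbonyl)amino on a saturated chain carbon bound to an aromatic carbon. Going by the values given here, no step between two measured compounds isolates this change, so its size is open; the two measured values show only that a different amide arrangement in compound 2 came with a lower number than compound 1.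

Compound 3 is expected to give a modestly lower number than compound 1 in this assay, a step of a 1.8-fold lower number from compound 1 to compound 3 (0.26 log units; within the scatter), though a result within the scatter would not surprise. The estimate for compound 3 is 18000 nM, with a range from 7000 nM to 45000 nM.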

Compound 3, half-maximal inhibitory concentration: 32900 nM
Compound 3: the middle estimate sits 1.8-fold (0.26 log units) below what was measured; measured number inside the range.
By their numbers in this assay, from the lowest: compound 2; then compounds 1 and 3 (each within the scatter of the next).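

Within the scatter, the two amide arrangements could not be told apart: in this assay, (phenylcarbamoyl)methyl in place of ((4-methylphenyl)carbonyl)amino on a saturated chain carbon bound to an aromatic carbon gives no change at the digits printed from compound 1 to compound 3 (within the scatter). Going by these compounds alone, this is the first single-place change in the set, and it shows that this position tolerates the swap of two groups with identical atom counts without any shift in the number, so the swap alone does not reproduce the lower number of compound 2. No supporting measurement bears on why the number stays put.

Compound 2 differs from compound 3 in more than one place, so the separate contributions of its chlorine-free core and its methyl stay unresolved. From the compounds shown here alone, whether a primary amine, a carboxylic acid or a longer chain at this position would shift the number also remains open.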